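Swapping the Trimethoxyphenyl Group for 4-Bromophenyl

The source may report more compounds than this note shows. Statements on the series, on what has been measured and on what is new or still open speak of the compounds shown alone.

compound 1 `COc1ccc(CN(C(=O)CSC(=S)N2CCN(C)CC2)c2cc(OC)c(OC)c(OC)c2)cc1` gives 1250 nM
compound 2 `COc1ccc(CN(C(=O)CSC(=S)N2CCN(C(=O)OC(C)(C)C)CC2)c2cc(OC)c(OC)c(OC)c2)cc1` gives 250 nM

For the measured compounds named here, in a functional assay on KYSE-450 cells (Homo sapiens) for inhibition, read by CCK-8 assay, with a stated time of 48 h (a higher number here means a weaker inhibitor, a lower number a stronger inhibitor), compound 2 gives 250 nM, the lower of the two numbers so far. Going by the values given here, the only measured step is a 5.0-fold lower number from compound 1 to compound 2 (0.70 log units; beyond the scatter), with tert-butoxycarbonyl in place of methyl on an amine nitrogen in a ring. Compound 3 `COc1ccc(CN(C(=O)CSC(=S)N2CCN(C(=O)OC(C)(C)C)CC2)c2ccc(Br)cc2)cc1` keeps the tert-butoxycarbonyl but carries 4-bromophenyl in place of 3,4,5-trimethoxyphenyl on an amide-type nitrogen. Among the compounds with values here, no measured step touches this group, so the data do not show what its exchange does. Within the data shown here, the one step available, a 5.0-fold lower number from compound 1 to compound 2 (0.70 log units; beyond the scatter), shows only how far a single change has moved the number here. A modest move towards a higher number in this assay is expected, though the direction is uncertain. The estimated change is a 1.6-fold higher number from compound 2 to compound 3 (0.20 log units; within the scatter). For compound 3 the expected value is 400 nM, with an estimated range from 100 nM to 1600 nM.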

Compound 3, half-maximal inhibitory concentration: > 20000 nM
Compound 3 was reported as a limit (the forecaster's own chance of this, stated with the estimate: 5%); middle value at least 50-fold (1.69 log units) away from the limit.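

For the compounds shown here, this position tolerates far less change than the earlier compounds could show. In this assay, going by these compounds alone, exchanging 3,4,5-trimethoxyphenyl for 4-bromophenyl on the amide-type nitrogen gives an at least 80-fold higher number from compound 2 to compound 3 (1.90 log units; beyond the scatter), a larger move than the only earlier step, a 5.0-fold lower number from compound 1 to compound 2 (0.70 log units; beyond the scatter), and the tert-butoxycarbonyl that compound 3 keeps does not preserve the activity of compound 2. The result for compound 3 is a limit and not an exact number, so the true size of this step stays unknown: the limit of > 20000 nM in this assay, at which 1 of the 3 values shown sits.

The compounds shown cannot separate the removal of the three methoxy groups from the arrival of the bromine, since both happen in one step. A plain phenyl group or a 4-methoxyphenyl group on this nitrogen would be needed to tell these two parts of the change apart.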